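The source may hold more compounds than are shown below. What is called first, only, known or untested is meant among the compounds shown, and "the series" means these compounds.

Of the compounds shown here, three have so far been measured in a functional assay on HepG2 cells (Homo sapiens) for cytotoxicity, read by MTT assay, with a stated time of 72 h; a lower number here means a stronger inhibitor, a higher number a weaker inhibitor. Compound 1 `CNC(=O)c1cc(Oc2ccc(NC(=O)c3nn(-c4ccccc4F)c(=O)cc3C)cc2F)ccn1` reaches only a limit: in this assay compound 1 gives > 40000 nM, which is a limit and not a number. Compound 2 `Cc1cc(=O)n(-c2ccc(Br)cc2F)nc1C(=O)Nc1ccc(Oc2ncnc3ccsc23)cc1` gives 10600 nM in this assay, and compound 3 `Cc1cc(=O)n(-c2ccc(Br)cc2F)nc1C(=O)Nc1ccc(Oc2ncnc3sccc23)cc1` gives 6300 nM. Compound 3 therefore holds the lowest of the two numbers recorded, yet its nearest neighbour, compound 2, sits within the scatter, so the two cannot be told apart: a 1.7-fold lower number from compound 2 to compound 3 (0.23 log units; within the scatter) when the group on an oxygen on an aromatic ring is exchanged for its isomer.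

Compound 4 `Cc1ccc(-n2nc(C(=O)Nc3ccc(Oc4ncnc5sccc45)cc3)c(C)cc2=O)cc1` has not yet been measured. It differs from compound 3 in 4-methylphenyl in place of 4-bromo-2-fluorophenyl on an aromatic nitrogen. Among the compounds with values here, no measured step touches this part of the molecule; the single step in hand, a 1.7-fold lower number from compound 2 to compound 3 (0.23 log units; within the scatter), concerns the far end of the shared core and stayed within the scatter, while compound 1 offers only (the limit of > 40000 nM in this assay, at which 1 of the 3 values shown sits). With no guide of that kind, the expectation is a change of little more than the scatter, leaning toward a higher number. Compound 4 is estimated at 9000 nM, with a range from 3000 nM to 30000 nM. That estimate means a 1.4-fold higher number from compound 3 to compound 4 (0.15 log units; within the scatter), expected to be a small move.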

Compound 4, half-maximal inhibitory concentration: > 40000 nM
Compound 4 gave a limit, no number; the forecaster's own chance of this, stated with the estimate: 20%; middle value at least 4.4-fold (0.64 log units) from the limit.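

Exchanging the group on the aromatic nitrogen gives an at least 6.3-fold higher number from compound 3 to compound 4 (0.80 log units; beyond the scatter), so this position can shift the read-out in this assay by more than the scatter, which the exchange of isomers at the far end of the molecule did not do. The change is not a single-atom edit: bromine and fluorine leave together and a methyl group enters, so the step shows only that 4-bromo-2-fluorophenyl and 4-methylphenyl are not interchangeable here, and it does not show which atom matters. Compound 4 reaches a limit rather than a number, so the step has a minimum size but no known full size, and the compound joins the values that cannot be ranked against each other: the limit of > 40000 nM in this assay, at which 2 of the 4 values shown sit.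

The compounds shown leave open whether the fluorine, the bromine or the methyl group accounts for the step, and no cause can be given for it. A chlorine atom, a methoxy group or an amine in place of the bromine, with the fluorine kept, would help to separate these contributions at this position.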